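Trading One Imidazole for Another on a Shared Core

The compounds below may be only part of what the source reports. "The series", "measured", "known", "first", "only" and "open" are said of these compounds alone.

Of the compounds shown here, two with the same core have been tested so far in a functional assay on HUVEC cells (Homo sapiens), read by scintillation counting and thymidine incorporation, with a stated time of 24 h; a higher number here means a weaker inhibitor, a lower number a stronger inhibitor. Compound 1 `CCC(C)n1ncn(-c2ccc(N3CCN(c4ccc(OC[C@@H]5CO[C@@](CBr)(c6ccc(Cl)cc6Cl)O5)cc4)CC3)cc2)c1=O` carries bromo on a saturated chain carbon bound to a saturated ring carbon and gives 569 nM. Compound 2 `CCC(C)n1ncn(-c2ccc(N3CCN(c4ccc(OC[C@@H]5CO[C@@](Cn6ccnc6C(C)C)(c6ccc(Cl)cc6Cl)O5)cc4)CC3)cc2)c1=O` has 2-isopropyl-1H-imidazol-1-yl in that place and gives 84 nM, the lower of the two numbers, which makes it the stronger inhibitor of the pair.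

Among the measured compounds shown here, compound 3 `CCC(C)n1ncn(-c2ccc(N3CCN(c4ccc(OC[C@@H]5CO[C@@](Cn6cc(C(F)(F)F)nc6C)(c6ccc(Cl)cc6Cl)O5)cc4)CC3)cc2)c1=O` keeps that core and changes only this group, with 2-methyl-4-(trifluoromethyl)-1H-imidazol-1-yl in place of 2-isopropyl-1H-imidazol-1-yl (2-methyl-4-(trifluoromethyl)-1H-imidazol-1-yl in place of 2-isopropyl-1H-imidazol-1-yl on a saturated chain carbon bound to a saturated ring carbon). For the measured compounds named here, the only measured step at this place is a 6.8-fold lower number from compound 1 to compound 2 (0.83 log units; beyond the scatter). That step replaced bromo with an imidazole, whereas compound 3 remains an imidazole, so it offers only a loose guide. Going by the values given here, no measured pair compares two imidazoles, and the direction of any change is uncertain. A large step therefore seems unlikely, with at most a slight rise in the number. The expected step is small, a 1.4-fold higher number from compound 2 to compound 3 (0.15 log units; within the scatter). Compound 3 is estimated at 120 nM, with an expected range of 40 nM to 350 nM.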

Compound 3, half-maximal inhibitory concentration: 441 nM
Compound 3: middle estimate off by 3.7-fold (0.57 log units), on the low side; measured number above the stated range.
By their numbers in this assay, from the lowest: compound 2; then compounds 3 and 1 (each within the scatter of the next).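

In this assay, exchanging one imidazole for another at this place is not a neutral change: the step is a 5.3-fold higher number from compound 2 to compound 3 (0.72 log units; beyond the scatter) and lies beyond the scatter, so which imidazole is attached matters, and not just whether one is there. The bromo compound gives a further lesson, as a 1.3-fold lower number from compound 1 to compound 3 (0.11 log units; within the scatter) lies within the scatter, which means compound 3 cannot be told apart from compound 1; an imidazole on a saturated chain carbon bound to a saturated ring carbon is therefore not enough by itself to give the lower number seen for compound 2. No measurement available here bears on the reason for this difference.

The step from compound 2 to compound 3 changes two things at once, as isopropyl gives way to methyl and a trifluoromethyl group is added, so the compounds shown cannot say which of these carries the loss. Among the compounds shown here, it also remains open where 2-methyl-1H-imidazol-1-yl, with only one of those two changes, would fall, and how a simple amine would compare at this place.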